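Lengthening the Amide Substituent: Cyclopropyl to Cyclopropylmethyl

This account rests on a few compounds, and the source may have more. Where it says the series, first, only, none or still open, it means among the compounds named here.

Measured compounds:
Compound 1 `CCNC(=O)[C@H]1O[C@@H](n2cnc3c(NCc4cccc(I)c4)nc(Cl)nc32)[C@H](O)[C@@H]1O`: 0.891 nM
Compound 2 `O=C(NC1CC1)[C@H]1O[C@@H](n2cnc3c(NCc4cccc(I)c4)nc(Cl)nc32)[C@H](O)[C@@H]1O`: 2.95 nM

In an assay on CHO cells for displacement of a labelled ligand from adenosine receptor A3 (Homo sapiens) (on this read-out lower numbers stand for stronger inhibition and higher numbers for weaker inhibition), compound 2 gives the higher of the two numbers, and the step of a 3.3-fold higher number from compound 1 to compound 2 (0.52 log units; beyond the scatter) shows the cyclopropyl amide binding less tightly than the ethyl amide. Compound 3 `O=C(NCC1CC1)[C@H]1O[C@@H](n2cnc3c(NCc4cccc(I)c4)nc(Cl)nc32)[C@H](O)[C@@H]1O` carries the change (cyclopropylmethyl in place of cyclopropyl on an amide-type nitrogen). Going by the values given here, no measured step covers this exact change; the only one known is a 3.3-fold higher number from compound 1 to compound 2 (0.52 log units; beyond the scatter), a modest loss when the amide group grew. A small further move, or none beyond the scatter, is therefore expected for compound 3 in this assay, a step of a 1.2-fold higher number from compound 2 to compound 3 (0.07 log units; within the scatter), with an estimated value of 3.5 nM in the range 1.2 nM to 10 nM.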

Compound 3, inhibition constant: 3.63 nM
Beside the measured number, compound 3's estimate is 1.0-fold (0.02 log units) below it; low and high end bracket the measured number.
By their numbers in this assay, from the lowest: compound 1; then compounds 2 and 3 (each within the scatter of the next).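

On the amide-type nitrogen, cyclopropylmethyl in place of cyclopropyl gives a 1.2-fold higher number from compound 2 to compound 3 (0.09 log units; within the scatter) in this assay, so this position accepts the larger group with no difference beyond the scatter. Measured against the ethyl amide, the step is a 4.1-fold higher number from compound 1 to compound 3 (0.61 log units; beyond the scatter), which places both ring-bearing amides on the weaker side of the ethyl amide. Nothing shown here explains these numbers. Still open, on these data alone, is whether a longer chain such as butyl, or a larger ring such as cyclobutyl, would stay close to these values on the same nitrogen.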